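The compounds below may be only part of what the source reports. "The series", "measured", "known", "first", "only" and "open" are said of these compounds alone.

Measured compounds:
- compound 1 `CCCCC(=O)Nc1ccc(N2CCN(c3ccc(OC[C@@H]4CO[C@@](Cn5cncn5)(c5ccc(Cl)cc5Cl)O4)cc3)CC2)cc1`: 5340 nM
- compound 2 `O=C(CC1CCOCC1)Nc1ccc(N2CCN(c3ccc(OC[C@@H]4CO[C@@](Cn5cncn5)(c5ccc(Cl)cc5Cl)O4)cc3)CC2)cc1`: 10000 nM

Among the compounds with values here, in a functional assay on A549 cells (Homo sapiens) for inhibition, read by MTT assay, with a stated time of 48 h (on this read-out higher numbers stand for weaker inhibition and lower numbers for stronger inhibition), compound 1 gives the lower of the two numbers, and the single step that separates it from compound 2, a 1.9-fold higher number from compound 1 to compound 2 (0.27 log units; within the scatter), swaps a chain for a saturated ring on the carbon bound to the carbonyl and stays within the scatter. Compound 3 `O=C(Nc1ccc(N2CCN(c3ccc(OC[C@@H]4CO[C@@](Cn5cncn5)(c5ccc(Cl)cc5Cl)O4)cc3)CC2)cc1)c1cccs1` changes the same amide end of the shared core in another way: thiophen-2-yl in place of butyl on a carbonyl carbon. Within the data shown here, no measured step puts an aromatic ring directly on that carbonyl carbon, so the only guide is the step from compound 1 to compound 2, which shows that reshaping this end of the molecule left the number essentially unchanged. On that basis the step of a 1.0-fold higher number from compound 1 to compound 3 (0.01 log units; within the scatter) is expected to be small, with no clear direction beyond the scatter. Compound 3 is therefore estimated at 5500 nM in this assay, with a range from 2500 nM to 12000 nM.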

Compound 3, half-maximal inhibitory concentration: 4330 nM
For compound 3 the middle estimate is 1.3-fold (0.10 log units) above the measured one, and the stated range covers the measured number.
By their numbers in this assay, from the lowest: compounds 3, 1 and 2 (each within the scatter of the next, the first and the last beyond it).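

In this assay, an aromatic ring can sit directly on the carbonyl carbon without moving the number beyond the scatter: thiophen-2-yl in place of butyl gives a 1.2-fold lower number from compound 1 to compound 3 (0.09 log units; within the scatter). Set against the (oxan-4-yl)methyl group, the same ring gives a 2.3-fold lower number from compound 2 to compound 3 (0.36 log units; beyond the scatter), a modest step and the only one among these compounds that clears the scatter. Nothing available here accounts for that difference.

The compounds shown leave open whether a plain phenyl ring or a longer chain on this carbonyl carbon would match thiophen-2-yl or move the number further. They also leave open what an amine or a carboxylic acid carried at this end of the molecule would do to the number.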